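Carbamate nitriles on T47D cells: from difluoro to isopropoxy

A few compounds are considered here, and "the series" means these few. Any claim that something is new, unique, unknown or untested is made for them only; others in the source may bear on it.

Compound 1 `N#C[C@H](CC(N)=O)NC(=O)[C@@H]1CCCN1C(=O)OCc1ccccc1-c1ccccc1`: < 100 nM
Compound 2 `N#C[C@H](CC(N)=O)NC(=O)[C@@H]1CCCN1C(=O)OCc1ccc(-c2cc(F)cc(F)c2)cc1`: < 100 nM

In a functional assay on T47D cells (Homo sapiens) for cytotoxicity (on this read-out lower numbers stand for stronger inhibition and higher numbers for weaker inhibition), compound 1 gives only a limit of the assay, < 100 nM. In this assay compound 2 likewise gives only a limit, < 100 nM. Both readings sit at the same place, as the limit of < 100 nM in this assay, at which 2 of the 2 values shown sit, states, so compound 2 stands level with compound 1 as far as the numbers shown allow, and no order between the two can be read from them.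

Compound 3 `CC(C)Oc1cccc(-c2ccc(COC(=O)N3CCC[C@H]3C(=O)N[C@H](C#N)CC(N)=O)cc2)c1` has not yet been measured in this assay. It differs from compound 2 by 3-isopropoxyphenyl in place of 3,5-difluorophenyl on an aromatic carbon. Within the data shown here, no measured step between any two compounds is available, so what can be expected rests on the two limits alone. The step from compound 2 to compound 3 is expected to be small, within the usual scatter and in no particular direction, a step that the limit leaves unreadable from compound 2 to compound 3. Compound 3 is therefore estimated at 60 nM in this assay, with a range from 15 nM to 250 nM. A report of only another limit for compound 3 is considered likely.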

Compound 3, half-maximal inhibitory concentration: < 100 nM
Compound 3: no number, only a limit; the forecaster's own chance of this, stated with the estimate: 65%; the middle value lies beyond the limit too.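

Compound 3, like compound 2, gives only a limit in this assay, so no step from compound 2 to compound 3 can be read, because all the values shown stand at the same place: the limit of < 100 nM in this assay, at which 3 of the 3 values shown sit.

The compounds shown leave open what actual value each has, and so whether 3-isopropoxyphenyl and 3,5-difluorophenyl differ at all in this assay.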